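From 1,3-benzothiazol-2-yl to chloro on compound 2

The compounds below may be only part of what the source reports. "The series", "measured", "known", "first", "only" and "open" are said of these compounds alone.

Of the compounds shown here, three have been tested in an ADME assay on HepG2 cells (Homo sapiens) for cytotoxicity, with a stated time of 72 h; a higher number here means that more compound is needed for the effect, a lower number that less compound is needed. Compound 1 `O=C(O)COc1cc(Cl)c(C(=O)Nc2cccc(-c3nc4ccccc4s3)c2)cc1[N+](=O)[O-]` gives > 25000 nM, which is a limit of the assay and not a number. Compound 2 `O=C(Nc1ccc(-c2nc3ccccc3s2)cc1)c1cc([N+](=O)[O-])ccc1Cl` gives > 27000 nM, which is also a limit. Compound 3 `COc1ccc(-c2nc3ccccc3s2)cc1NC(=O)c1cc([N+](=O)[O-])c(N2CCN(C)CC2)cc1Cl` gives > 25000 nM, again a limit. Compound 2 therefore stands where the other two stand: none of the three has an exact number, and no order among them can be read. For the measured compounds named here, no two of them differ in one place only, so no measured step is available as a guide.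

Compound 4 `O=C(Nc1ccc(Cl)cc1)c1cc([N+](=O)[O-])ccc1Cl` has not yet been measured. It differs from compound 2 by a single change: chloro in place of 1,3-benzothiazol-2-yl on an aromatic carbon. Chloro takes the place of 1,3-benzothiazol-2-yl on an aromatic carbon, para to a large group.

In this assay, no step beyond the usual scatter is expected, in either direction. That expectation rests on the limit of compound 2, > 27000 nM, and on the same kind of result for compound 1 and compound 3. The expected change is a step that the limit leaves unreadable from compound 2 to compound 4. The result may well be only a limit again. For compound 4 the estimated value is 30000 nM, with an expected range from 12000 nM to 60000 nM.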

Compound 4, half-maximal effective concentration: > 27000 nM
Compound 4: a limit, no number; the forecaster's own chance of this, stated with the estimate: 75%; the middle value does not contradict the limit.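

In this assay compound 2 and compound 4 both give a limit of the assay rather than a number, so no step from one to the other can be read: the limit of > 27000 nM in this assay, at which 2 of the 4 values shown sit.

The compounds shown leave open what concentration of any of them would produce the effect, and so how they rank.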